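Replacing the 2,4-difluorobenzyl group of compound 2

This account rests on a few compounds, and the source may have more. Where it says the series, first, only, none or still open, it means among the compounds named here.

Measured in an ADME assay on the whole organism (Rattus norvegicus, strain Sprague-Dawley) for pharmacokinetics, read by LC-MS, at a dose of 5 mg/kg by the oral route; on this read-out higher numbers stand for higher oral bioavailability and lower numbers for lower oral bioavailability:
Compound 1 `Cc1nc(C)c([C@H](OC(C)(C)C)C(=O)O)c(N2CCC(C)(C)CC2)c1-c1ccc2c(c1)CCN(Cc1cccc(F)c1C)C2`: 64%
Compound 2 `Cc1nc(C)c([C@H](OC(C)(C)C)C(=O)O)c(N2CCC(C)(C)CC2)c1-c1ccc2c(c1)CCN(Cc1ccc(F)cc1F)C2`: > 100% (a limit)

Compound 2 gives > 100%, which is a limit of the assay and not a number. Compound 3 `Cc1nc(C)c([C@H](OC(C)(C)C)C(=O)O)c(N2CCC(C)(C)CC2)c1-c1ccc2c(c1)CCN(c1nccc(-c3cnccn3)n1)C2` carries a different group: a group of 12 heavy atoms (8 carbon, 4 nitrogen; 2 six-membered aromatic rings with 2 hetero atoms each) in place of a group of 9 heavy atoms (7 carbon, 2 fluorine; one six-membered aromatic ring of carbon only), on an amine nitrogen in a ring. Among the measured compounds shown here, one measured step bears on this change, a number at least 36 percentage points higher from compound 1 to compound 2 (beyond the scatter), and it is large. A large fall is therefore expected in this assay, as compound 1 gives only 64% with another group in that part of the molecule. The expected change is a number at least 50 percentage points lower from compound 2 to compound 3 (beyond the scatter). Compound 3 is estimated at 50%, with an expected range of 20% to 85%.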

Compound 3, oral bioavailability: 38%
Compound 3: middle estimate off by 12 percentage points, on the high side; the range from low to high includes it.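

In this assay, compound 3 is the first compound shown with 2 six-membered aromatic rings with 2 hetero atoms each on the amine nitrogen in a ring, and the change brings a number at least 62 percentage points lower from compound 2 to compound 3 (beyond the scatter). The size of this step is only a bound, since the value of compound 2 is a limit of the assay and not a number: the limit of > 100% in this assay, at which 1 of the 3 values shown sits.

The fall is smaller against the other benzyl compound, with a number 26 percentage points lower from compound 1 to compound 3 (beyond the scatter), yet it is still beyond the scatter. The compounds shown leave open which part of the entering group carries the fall, and how a single pyridine ring or a benzyl group bearing a morpholine would behave on that nitrogen.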